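A few compounds are considered here, and "the series" means these few. Any claim that something is new, unique, unknown or untested is made for them only; others in the source may bear on it.

Measured compounds:

Compound 1 `COc1ccc2nc(NC(=O)c3cn(-c4ccccc4)nc3-c3ccc(Cl)cc3)sc2c1`: 21200 nM
Compound 2 `Cc1ccc2nc(NC(=O)c3cn(-c4ccccc4)nc3-c3ccc(Cl)cc3)sc2c1`: 33200 nM
Compound 3 `COc1ccc(-c2nn(-c3ccccc3)cc2C(=O)Nc2nc3ccc(OC)cc3s2)cc1`: 5890 nM

All three were tested in a functional assay on U-87MG ATCC cells for cytotoxicity against U-87 MG (Homo sapiens), read by MTT assay, with a stated time of 72 h; a higher number here means a weaker inhibitor, a lower number a stronger inhibitor. Compound 1 and compound 2 share a core and differ only at one point: methyl in place of methoxy on an aromatic carbon. This gave a 1.6-fold higher number from compound 1 to compound 2 (0.19 log units; within the scatter), so the two values cannot be told apart with confidence. Compound 3 differs from compound 1 in its other ring: methoxy in place of chloro on an aromatic carbon. Here the change gave a 3.6-fold lower number from compound 1 to compound 3 (0.56 log units; beyond the scatter), a difference that does stand out from the noise of repeated testing.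

Compound 4 `COc1ccc(-c2nn(-c3ccccc3)cc2C(=O)Nc2nc3ccc(C)cc3s2)cc1` has not yet been measured. It differs from compound 3 by methyl in place of methoxy on an aromatic carbon. This is the same change that turns compound 1 into compound 2, made at the same place on the same kind of ring, but on the core of compound 3 rather than that of compound 1. Since this change produced a 1.6-fold higher number from compound 1 to compound 2 (0.19 log units; within the scatter), the expectation is that it will move the value of compound 4 only a little, and most likely in the same direction. In this assay compound 4 is therefore expected to give about 8500 nM, with a plausible range from 4000 nM to 20000 nM. Within the data shown here, the estimated step from compound 3 is a 1.4-fold higher number from compound 3 to compound 4 (0.16 log units; within the scatter), which rests on the one earlier instance of this change and so carries real uncertainty.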

Compound 4, half-maximal inhibitory concentration: > 50000 nM
Compound 4: a limit, no number; the forecaster's own chance of this, stated with the estimate: 5%; middle value at least 5.8-fold (0.76 log units) from the limit.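

In this assay compound 4 gives > 50000 nM, which is a limit of the assay and not a number. Methyl in place of methoxy, going from 6-methoxy-1,3-benzothiazol-2-yl to 6-methyl-1,3-benzothiazol-2-yl, gives an at least 8.4-fold higher number from compound 3 to compound 4 (0.92 log units; beyond the scatter), so the effect of this change does not carry over unchanged from the core of compound 1 to the core of compound 3: the same change on two cores in this assay, a 1.6-fold higher number (0.19 log units; within the scatter) from compound 1 to compound 2 and an at least 8.4-fold higher number (0.92 log units; beyond the scatter) from compound 3 to compound 4, at least 5.4-fold (0.73 log units) apart, beyond the scatter of two such steps The other change, methoxy in place of chloro on an aromatic carbon, gives an at least 1.5-fold higher number from compound 2 to compound 4 (0.17 log units; that floor lies within the scatter) and does not carry over either, but with only a limit for compound 4 these steps are floors rather than true sizes, and the data do not show what lies behind the mismatch: the same change on two cores in this assay, a 3.6-fold lower number (0.56 log units; beyond the scatter) from compound 1 to compound 3 and an at least 1.5-fold higher number (0.17 log units; that floor lies within the scatter) from compound 2 to compound 4, at least 5.4-fold (0.73 log units) apart, beyond the scatter of two such steps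

Among these compounds, the four compounds test only two changes on two cores, so it stays open whether the mismatch would also appear on other cores or in other cell lines. On these data alone, it is also open how other groups at these same places, such as an amine, a carboxylic acid or a longer chain, would behave in this assay.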